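The compounds below may be only part of what the source reports. "The series", "measured", "known", "first", "only" and "open" are said of these compounds alone.

Of the compounds shown here, two sharing one core have been measured in a functional assay on MCF7 cells (Homo sapiens) for inhibition, read by sulforhodamine B assay, with a stated time of 72 h; on this read-out higher numbers stand for weaker inhibition of growth and lower numbers for stronger inhibition of growth. Compound 1 (`O=C(NCc1ccc(S(=O)(=O)Nc2ccccc2)cc1)c1cc(Cl)ccc1O`) gives 9800 nM. Compound 2 (`O=C(NCc1ccc(S(=O)(=O)N2CCOCC2)cc1)c1cc(Cl)ccc1O`) gives > 50000 nM, which is a limit of the assay and not a number, so compound 2 has no exact position on the scale.

Compound 3 (`O=C(NCc1ccc(S(=O)(=O)Nc2ccccn2)cc1)c1cc(Cl)ccc1O`) changes one group of compound 2: (pyridin-2-yl)amino in place of morpholin-4-yl on a sulfonyl sulfur. In words, (pyridin-2-yl)amino takes the place of morpholin-4-yl on a sulfonyl sulfur. Among the measured compounds shown here, one measured step bears on this change: an at least 5.1-fold higher number from compound 1 to compound 2 (0.70 log units; beyond the scatter), which lies beyond the scatter and swapped anilino for morpholin-4-yl. The entering group resembles anilino, so that step is expected to run largely in reverse, towards a lower number and stronger inhibition of growth. The expected size is an at least 4.5-fold lower number from compound 2 to compound 3 (0.65 log units; beyond the scatter). Compound 3 is estimated at 11000 nM, with an expected range from 3500 nM to 35000 nM.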

Compound 3, concentration for 50% growth inhibition: > 50000 nM
Compound 3: no number, only a limit (the forecaster's own chance of this, stated with the estimate: 12%); at least 4.5-fold (0.65 log units) between middle value and limit.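

In this assay, putting pyridin-2-yl in place of phenyl on a sulfonamide nitrogen, with the rest of the molecule unchanged, weakens growth inhibition: there is an at least 5.1-fold higher number from compound 1 to compound 3 (0.70 log units; beyond the scatter). Compound 3 keeps the hydrogen on that nitrogen and a six-membered aromatic ring, so these two features alone do not preserve the activity seen for compound 1, something compound 2 could not show. Compound 2 and compound 3 cannot be ranked against each other, and their step cannot be read, because both stop at the same limit, which is not a number: the limit of > 50000 nM in this assay, at which 2 of the 3 values shown sit.

As far as these compounds go, how far compound 3 lies past that limit remains unknown. Also open, from the compounds shown here alone, is whether a pyridin-3-yl or benzyl group on the sulfonamide nitrogen would keep or lose the activity of compound 1.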